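The source may report more compounds than this note shows. Statements on the series, on what has been measured and on what is new or still open speak of the compounds shown alone.

Measured compounds:
compound 1 `CNC(=O)Nc1c(C)c(C(OC(C)(C)C)C(=O)O)c(-c2ccc(C)c(C)c2)c(C)c1-c1ccc(C)c(C)c1` — 20000 nM
compound 2 `Cc1ccc(-c2c(C)c(-c3ccc4c(c3C)CCCO4)c(C(OC(C)(C)C)C(=O)O)c(C)c2NS(C)(=O)=O)cc1C` — 24000 nM
compound 3 `Cc1ccc(-c2c(C)c(-c3ccc4c(c3)CCCO4)c(C(OC(C)(C)C)C(=O)O)c(C)c2NS(C)(=O)=O)cc1C` — 28000 nM

In an ADME assay on MT4 cells (Homo sapiens) for cytotoxicity, read by MTT assay, with a stated time of 4 days (a lower number here means that less compound is tolerated, a higher number that more compound is tolerated), compound 1 gives 20000 nM. Compound 2 gives 24000 nM and compound 3 gives 28000 nM in this assay. Compound 1 has the lowest of the three numbers, but its gaps to compound 2 and to compound 3 both lie within the scatter, so the three compounds cannot be placed in order on what is shown.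

Going by the values given here, the only step measured between two compounds that differ in one place is a 1.2-fold higher number from compound 2 to compound 3 (0.07 log units; within the scatter), which is a change on an aromatic carbon and does not touch the nitrogen substituent.

Among the compounds with values here, compound 4 `Cc1ccc(-c2c(C)c(-c3ccc(C)c(C)c3)c(C(OC(C)(C)C)C(=O)O)c(C)c2NS(=O)(=O)C2CC2)cc1C` differs from compound 1 as follows: cyclopropylsulfonyl in place of methylcarbamoyl on a nitrogen on an aromatic ring No measured step shares this change. What can be said is that compound 2 and compound 3, which carry a sulfonyl group on that nitrogen, fall within the scatter of compound 1, and nothing among the three compounds suggests a shift beyond the scatter for this assay. For compound 4 the expected step is a 1.1-fold higher number from compound 1 to compound 4 (0.04 log units; within the scatter). Compound 4 is therefore estimated at 22000 nM, with a range from 10000 nM to 45000 nM.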

Compound 4, half-maximal cytotoxic concentration: 11000 nM
Compound 4: middle estimate off by 2.0-fold (0.30 log units), on the high side; low and high end bracket the measured number.
By their numbers in this assay, from the lowest: compounds 4, 1, 2 and 3 (each within the scatter of the next, the first and the last beyond it).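

In this assay, the exchange of methylcarbamoyl for cyclopropylsulfonyl on a nitrogen on an aromatic ring gives a 1.8-fold lower number from compound 1 to compound 4 (0.26 log units; within the scatter), and this is the first step shown that reads a change at this nitrogen directly. On this one pair, then, the nitrogen accepts a substantial exchange, from an open group to one carrying a three-membered ring of carbon only and a sulfur, without the number moving beyond the usual scatter of the assay. Nothing available explains the size or the direction of this step, which therefore stands as an observation on a single pair of compounds.

The compounds shown leave open whether this tolerance extends to other groups on the same nitrogen, such as a free amine, an acetyl group or a longer chain like butylsulfonyl, any of which might or might not take the number beyond the scatter. They also leave open whether the same exchange would give a step of similar size on the cores of compound 2 and compound 3, where the other aromatic group differs.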